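Replacing penta-1,3-dien-1-yl with 2-chloroethyl on a carbonyl carbon

This account rests on a few compounds, and the source may have more. Where it says the series, first, only, none or still open, it means among the compounds named here.

Measured so far in a functional assay on HCT-116 cells (Homo sapiens) for inhibition, read by MTT assay, with a stated time of 48 h (a higher number here means a weaker inhibitor, a lower number a stronger inhibitor), with these results:
compound 1 `C/C=C/C=C/C(=O)N(Cc1ccc(OC)c(O)c1)c1cc(OC)c(OC)c(OC)c1` gives 180 nM
compound 2 `COc1ccc(N(Cc2cc(OC)c(OC)c(OC)c2)C(=O)CCl)cc1O` gives 22500 nM
compound 3 `C/C=C/C(=O)N(Cc1ccc(OC)c(C)c1)c1cc(OC)c(OC)c(OC)c1` gives 23500 nM

Compound 1 holds the lowest number of the three and is the strongest inhibitor among them. Compound 2 and compound 3 both lie far beyond the scatter from it, and they stand within the scatter of each other, so no order is drawn between those two.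

Compound 4 `COc1ccc(CN(C(=O)CCCl)c2cc(OC)c(OC)c(OC)c2)cc1O` has not yet been measured. Its difference from compound 1 is 2-chloroethyl in place of penta-1,3-dien-1-yl on a carbonyl carbon with 2-chloroethyl in place of penta-1,3-dien-1-yl on a carbonyl carbon whose other neighbour is an amide-type nitrogen. Among the measured compounds shown here, no measured step between compounds differing in one place is available, so the judgement rests on the values alone. Only compound 1 at 180 nM has a low number, whereas compound 2 at 22500 nM and compound 3 at 23500 nM mark where the rest of this small set falls. A large rise is therefore expected, with an estimated step of an 83-fold higher number from compound 1 to compound 4 (1.92 log units; beyond the scatter) toward a weaker inhibitor, well beyond the scatter. In this assay the expected value for compound 4 is 15000 nM (estimated range 4000 nM to 50000 nM).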

Compound 4, half-maximal inhibitory concentration: 150 nM
Beside the measured number, compound 4's estimate is 100-fold (2.00 log units) above it; measured number outside the range, below it.
By their numbers in this assay, from the lowest: compounds 4 and 1 (each within the scatter of the next); then compounds 2 and 3 (each within the scatter of the next).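

Among the compounds shown here, the step of a 1.2-fold lower number from compound 1 to compound 4 (0.08 log units; within the scatter) is the first reading of a single change at this position, and in this assay it shows that 2-chloroethyl and penta-1,3-dien-1-yl cannot be told apart on a carbonyl carbon whose other neighbours are an amide-type nitrogen. The group that leaves has 5 heavy atoms and 2 double bonds outside aromatic rings, while the group that enters has 3 heavy atoms, one of them chlorine, and no such double bonds, so neither that chain length nor those double bonds are needed at this place for a value at this level. No supporting data are available here to explain why the two groups give matching results.

As far as these compounds go, what stays open is whether this level would hold with other groups on the same carbonyl carbon, such as a plain ethyl chain, a longer chloroalkyl chain or a chain carrying an amine. The compounds shown also leave open whether the chlorine of compound 4 matters at all, as no close analogue with a hydrogen in its place appears among them.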